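A Pyridine Ring Enters a Non-Toxic Amide Series

The compounds below may be only part of what the source reports. "The series", "measured", "known", "first", "only" and "open" are said of these compounds alone.

The compounds here share one core, seen in compound 1 `COc1ccc2nc(C)cc(OCC(=O)NCc3cc(C)cc(C)c3)c2c1`. They were tested in a toxicity assay on HepG2 cells (Homo sapiens) for inhibition, read by CellTiter-Glo, with a stated time of 48 h; on this read-out lower numbers stand for stronger inhibition and higher numbers for weaker inhibition. Compound 1 gives > 100000 nM in this assay, which is a limit of the assay rather than a number. Two related compounds behave the same way. Compound 2 `COc1ccc2nc(C)cc(OCC(=O)Nc3cc(OC)c(Cl)cc3OC)c2c1` gives > 100000 nM in this assay, again a limit. Compound 3 `COc1ccc2nc(C)cc(OCC(=O)Nc3cc(OC)c(OC)c(OC)c3)c2c1` gives > 100000 nM in this assay, also a limit. So compound 1 stands where every measured value stands: the limit of > 100000 nM in this assay, at which 3 of the 3 values shown sit.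

Compound 4 `COc1ccc2nc(C)cc(OCC(=O)Nc3c(C)cncc3C)c2c1` has not been measured. It differs from compound 1 in one place: 3,5-dimethylpyridin-4-yl in place of 3,5-dimethylbenzyl on an amide-type nitrogen. For the measured compounds named here, no measured pair shows what this change does here, so the expectation rests only on the shared absence of measurable toxicity across compound 1, compound 2 and compound 3. The expected step of a number no higher from compound 1 to compound 4 (the limit leaves the size open) is none beyond the scatter. The estimate for compound 4 is 100000 nM, expected to lie between 50000 nM and 300000 nM, with a good chance that only a limit is reported again.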

Compound 4, half-maximal inhibitory concentration: 12600 nM
Compound 4: the middle estimate sits 7.9-fold (0.90 log units) above what was measured, outside the stated range (below it).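

In this assay, putting 3,5-dimethylpyridin-4-yl in place of 3,5-dimethylbenzyl on the amide-type nitrogen gives an at least 7.9-fold lower number from compound 1 to compound 4 (0.89 log units; beyond the scatter). This shows that the group at this place can decide whether any effect on these cells is seen at all, and since compound 1 has only a limit, the true step may be larger than the one printed. Among the compounds shown, only compound 4 has a measured number, while the others rest on a limit: the limit of > 100000 nM in this assay, at which 3 of the 4 values shown sit.

The change swaps the ring and removes the benzyl carbon together, so the compounds shown cannot say which of the two matters, and a 3,5-dimethylphenyl group on the same nitrogen would help to separate them. From the compounds shown here alone, whether a pyridine ring without the two methyl groups gives a similar number also remains open.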